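Ethyl-to-methyl step on the core nitrogen of compound 2

A few compounds are considered here, and "the series" means these few. Any claim that something is new, unique, unknown or untested is made for them only; others in the source may bear on it.

Among the measured compounds shown here, in a functional assay on CHO cells for antagonist activity at adenosine receptor A2b (Homo sapiens), read by 33P incorporation, with a stated time of 20 min (a higher number here means a weaker inhibitor, a lower number a stronger inhibitor), compound 2 `CCn1c(-c2ccccc2)nc2c(NC3CCOC3)ncnc21` gives 11500 nM, the only finite number so far. Compound 1 `Cn1c(-c2ccccc2)nc2c(NC3CCCCC3)ncnc21` reaches only the assay limit of > 30000 nM, a limit rather than a number (the limit of > 30000 nM in this assay, at which 1 of the 2 values shown sits). Compound 3 `Cn1c(-c2ccccc2)nc2c(NC3CCOC3)ncnc21` is obtained from compound 2 by hydrogen in place of methyl on a saturated chain carbon bound to an aromatic nitrogen; the same difference, cut one bond further out, reads ethyl to methyl. For the measured compounds named here, with no measured step of this kind to lean on, a small loss toward weaker inhibition is expected, near the scatter, as the step of a 1.7-fold higher number from compound 2 to compound 3 (0.24 log units; within the scatter). Compound 3 is estimated at 20000 nM, within 8000 nM to 50000 nM.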

Compound 3, inhibition constant: 13300 nM
Compound 3: middle estimate off by 1.5-fold (0.18 log units), on the high side; low and high end bracket the measured number.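

Ethyl and methyl on the core nitrogen are not told apart in this assay, with a 1.2-fold higher number from compound 2 to compound 3 (0.06 log units; within the scatter). Among the compounds shown here, with methyl held, the first readable change at the other position is oxolan-3-yl in place of cyclohexyl on a nitrogen on an aromatic ring, with an at least 2.2-fold lower number from compound 1 to compound 3 (0.35 log units; beyond the scatter). That step rests on the value of compound 1, which is a limit and not a number: the limit of > 30000 nM in this assay, at which 1 of the 3 values shown sits.

Open, on these data alone, is whether a longer chain such as propyl on the core nitrogen departs from these two values. Also open, as far as these compounds go, is whether a piperidin-4-yl group in place of oxolan-3-yl gives a lower number.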